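Chloro in place of hydrogen on a chromanol core

A few compounds are considered here, and "the series" means these few. Any claim that something is new, unique, unknown or untested is made for them only; others in the source may bear on it.

The study examines three measured phenols in a physicochemical assay for acid dissociation. Compound 1 `CC1(C)CCc2cc(O)ccc2O1` gives 10.3, compound 2 `CC1(C)CCc2c(Cl)c(O)c(Cl)c(Cl)c2O1` gives 7.1, and compound 3 `CC1(C)CCc2c(cc(Cl)c(O)c2Cl)O1` gives 7.7. Among the measured compounds shown here, the only single-point step among them runs from compound 3 to compound 2, (chloro in place of hydrogen on an aromatic carbon), and in this assay it is a number 0.60 log units lower from compound 3 to compound 2 (beyond the scatter).

Compound 4 `CC1(C)CCc2cc(O)cc(Cl)c2O1` has not yet been measured. It differs from compound 1 by chloro in place of hydrogen on an aromatic carbon. This is the same kind of change as that from compound 3 to compound 2, though not the same: in the step from compound 3 to compound 2 the entering chloro sits ortho to a chloro group and para to a chloro group as well, whereas in compound 4 it does not. The difference between the core of compound 1 and the core of compound 3 is not broken down here.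

In this assay the step from compound 1 to compound 4 is expected to be a number 0.90 log units lower from compound 1 to compound 4 (beyond the scatter), resting on the step shown from compound 3 to compound 2, a number 0.60 log units lower from compound 3 to compound 2 (beyond the scatter). Compound 4 is therefore estimated at 9.4, between 8.9 and 9.9.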

Compound 4, acid dissociation constant: 9.8
Compound 4: middle estimate off by 0.40 log units, on the low side; low and high end bracket the measured number.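

In this assay the new step is a number 0.50 log units lower from compound 1 to compound 4 (beyond the scatter) and the earlier step is a number 0.60 log units lower from compound 3 to compound 2 (beyond the scatter) so chloro in place of hydrogen on an aromatic carbon lowers the number on both cores shown, and both steps are modest. This rests on two pairs only, with the entering chloro in different surroundings in each, so it shows a shared direction but does not show that a size read on one core can be carried over to another. Nothing given here speaks to why the number falls in either pair.

The compounds shown leave open how a nitrile or an amine on that same aromatic carbon of the core of compound 1 would move the number. They also leave open whether a second chloro on that core would lower it by a similar amount again, or whether the step would change with the chloro already present.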